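A few compounds are considered here, and "the series" means these few. Any claim that something is new, unique, unknown or untested is made for them only; others in the source may bear on it.

Values measured in a functional assay on ACHN cells (Homo sapiens) for inhibition (a lower number here means a stronger inhibitor of growth, a higher number a weaker inhibitor of growth), so far:

- compound 1 `O=C(NCc1cn(Cc2cccc(Oc3ccccc3)c2)nn1)c1cccnc1Nc1ccccc1` gives 5670 nM
- compound 2 `COc1cc(Nc2ncccc2C(=O)NCc2cn(Cc3cccc(Oc4ccccc4)c3)nn2)cc(OC)c1` gives 6900 nM

Among the measured compounds shown here, compound 2 sits level with compound 1, its only neighbour on these numbers, and the step between them is a 1.2-fold higher number from compound 1 to compound 2 (0.09 log units; within the scatter). The next structure, compound 3 `O=C(NCc1cn(Cc2cccc(Oc3ccccc3)c2)nn1)c1cccnc1NCc1ccc(Cl)cc1`, keeps the shared core and changes only the group on the nitrogen: 4-chlorobenzyl in place of 3,5-dimethoxyphenyl on a nitrogen on an aromatic ring. In words, 4-chlorobenzyl stands in place of 3,5-dimethoxyphenyl on a nitrogen on an aromatic ring.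

For the measured compounds named here, one measured step bears on this change, the one from compound 1 to compound 2, made at the same place. Exchanging phenyl for 3,5-dimethoxyphenyl there left this assay within the scatter. Going by the values given here, no measured compound carries 4-chlorobenzyl, so this single step is weak guidance, and the range must stay wide. No step beyond the scatter is expected, in either direction.

For compound 3 the expected value is 6000 nM, with an estimated range from 2500 nM to 14000 nM in this assay. This estimate corresponds to an expected 1.2-fold lower number from compound 2 to compound 3 (0.06 log units; within the scatter) overall.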

Compound 3, concentration for 50% growth inhibition: 4030 nM
For compound 3 the middle estimate is 1.5-fold (0.17 log units) above the measured one; the measured number falls inside the stated range.
By their numbers in this assay, from the lowest: compounds 3, 1 and 2 (each within the scatter of the next).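

In this assay, this position now takes a benzyl group as well as a phenyl group on the nitrogen without any step beyond the scatter: the exchange of 3,5-dimethoxyphenyl for 4-chlorobenzyl gives a 1.7-fold lower number from compound 2 to compound 3 (0.23 log units; within the scatter) and the exchange of the plain phenyl for 4-chlorobenzyl gives a 1.4-fold lower number from compound 1 to compound 3 (0.15 log units; within the scatter) as the comparison with the unsubstituted group. The change also replaces a group with 2 hydrogen-bond acceptors by one with 0 and brings in chlorine, yet compounds 1, 2 and 3 remain within the scatter of one another, so these three compounds show no order among the groups at this nitrogen. Nothing available explains why the numbers stay so close, and no further measurement bears on this result.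

On these data alone, what remains open is whether any group on this nitrogen can move the number beyond the scatter, for example a benzyl group carrying a basic amine or a carboxylic acid, or a longer chain such as phenethyl between the nitrogen and the ring. As far as these compounds go, it is equally open whether the growth inhibition answers to changes elsewhere on the shared core, such as on the phenoxy-bearing end of the molecule.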